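A few compounds are considered here, and "the series" means these few. Any claim that something is new, unique, unknown or untested is made for them only; others in the source may bear on it.

Measured so far:
compound 1, `Cc1nc(C(NC(=O)C(=O)Nc2ccc(Cl)cc2)C2CCCCN2C)sc1CCO`: 36000 nM
compound 2, `Cc1nc(C(NC(=O)C(=O)Nc2ccc(F)c(Cl)c2)C2CCCCN2)sc1CO`: > 77800 nM

In an ADME assay on TZM-b1 cells (Homo sapiens) for cytotoxicity, read by XTT assay, with a stated time of 3 days (on this read-out lower numbers stand for higher toxicity in this test and higher numbers for lower toxicity in this test), compound 1 gives 36000 nM. For compound 2 the record holds (the limit of > 77800 nM in this assay, at which 1 of the 2 values shown sits), a limit of the assay and not a number. Compound 2 thus stands in this assay only at > 77800 nM, with no measured value to compare against.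

Compound 3, `Cc1nc(C(NC(=O)C(=O)Nc2ccc(F)cc2F)C2CCCCN2)sc1CO`, differs from compound 2 by 2,4-difluorophenyl in place of 3-chloro-4-fluorophenyl on an amide-type nitrogen; the rest of the shared core is unchanged. Within the data shown here, no step between measured compounds is known, and compounds 1 and 2 differ in more than one place, so their two values show only that one sits at a number and the other at a limit. For an exchange of one halogenated phenyl for another, no step beyond the scatter in this assay is expected. The expected step from compound 2 to compound 3 is a step that the limit leaves unreadable from compound 2 to compound 3. Compound 3 is therefore estimated at 80000 nM, within 30000 nM to 200000 nM, most likely again as a limit.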

Compound 3, half-maximal cytotoxic concentration: > 87000 nM
Compound 3: a limit, no number; the forecaster's own chance of this, stated with the estimate: 70%; middle value at least 1.0-fold (0.03 log units) away from the limit.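

In this assay compound 2 gives only a limit, > 77800 nM. Compound 3 also gives only a limit, > 87000 nM. Among these compounds, no step between compound 2 and compound 3 can be read from these limits. The compounds shown leave open whether 2,4-difluorophenyl in place of 3-chloro-4-fluorophenyl shifts the half-maximal cytotoxic concentration at all.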